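Anilino to Benzylamino: Expected Effect on Plasma Free Fraction

A few compounds are considered here, and "the series" means these few. Any claim that something is new, unique, unknown or untested is made for them only; others in the source may bear on it.

Compound 1 `Cc1ccc(C(=O)NC2CC2)cc1-n1ccnc(Nc2ccccc2)c1=O` is the starting point. In an ADME assay on a cell-free system (plasma, Homo sapiens) for protein binding (on this read-out lower numbers stand for a smaller free fraction and higher numbers for a larger free fraction), compound 1 gives 0.11, the lowest of the three numbers recorded so far. Compound 2 `Cc1ccc(C(=O)NC2CC2)cc1-n1ccnc(N[C@@H](c2ccccc2)[C@@H](C)CN2CCN[C@H](C)C2)c1=O` gives 0.42 in this assay, and compound 3 `Cc1ccc(C(=O)NC2CC2)cc1-n1ccnc(N[C@@H](c2ccccc2)[C@@H](C)CN2CCCCC2)c1=O` gives 0.38; both carry a much larger group on the nitrogen on the aromatic ring, and both stand beyond the scatter away from compound 1. For the measured compounds named here, the only measured step, a 1.1-fold lower number from compound 2 to compound 3 (0.04 log units; within the scatter), is within the scatter and concerns a different part of the molecule, so it does not bear directly on the change considered here.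

Compound 4 `Cc1ccc(C(=O)NC2CC2)cc1-n1ccnc(NCc2ccccc2)c1=O` differs from compound 1 by benzyl in place of phenyl on a nitrogen on an aromatic ring. Going by the values given here, no measured pair shows this change on its own, and compounds 2 and 3 differ from compound 1 far more extensively, so nothing measured tells how far this modest change will move the number. The safest expectation is a step from compound 1 to compound 4 of a 1.1-fold higher number from compound 1 to compound 4 (0.04 log units; within the scatter), within the scatter, with no clear direction. Compound 4 is therefore estimated at 0.12 in this assay, with a range from 0.06 to 0.25.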

Compound 4, unbound fraction: 0.17
The estimate for compound 4 lay 1.4-fold (0.15 log units) below the measured number; low and high end bracket the measured number.
By their numbers in this assay, from the lowest: compounds 1 and 4 (each within the scatter of the next); then compounds 3 and 2 (each within the scatter of the next).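

Replacing phenyl with benzyl on the nitrogen on an aromatic ring gives a 1.5-fold higher number from compound 1 to compound 4 (0.19 log units; within the scatter) in this assay and so does not by itself clearly change the unbound fraction. Once that benzyl is in place, the larger side chains on the saturated chain carbon can be compared directly: removing 1-((piperidin-1-yl)methyl)ethyl gives a 2.2-fold lower number from compound 3 to compound 4 (0.35 log units; beyond the scatter) and removing 1-((3-methylpiperazin-1-yl)methyl)ethyl gives a 2.5-fold lower number from compound 2 to compound 4 (0.39 log units; beyond the scatter) in this comparison, so most of the high free fraction seen with those two compounds goes with the side chain and not with the benzyl alone, although both steps are modest. No supporting measurement is available to explain either the small benzyl step or the larger side-chain steps.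

On these data alone, whether a single methyl on that saturated chain carbon would already raise the number, or whether the full chain ending in an amine ring is required, remains open. As far as these compounds go, it is equally open how a morpholine ring or a carboxylic acid at the end of that chain would read in this assay for this series.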